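The source may hold more compounds than are shown below. What is called first, only, known or untested is meant among the compounds shown, and "the series" means these compounds.

The series shares one core, carried by compound 1 `O=C(/C(=C\c1c(O)cc(O)cc1O)Sc1ccccc1Br)c1ccc(Br)cc1`, compound 2 `O=C(/C(=C\c1c(O)cc(O)cc1O)S(=O)(=O)c1ccccc1Br)c1ccc(Br)cc1` and compound 3 `Cc1ccc(S/C(=C/c2c(O)cc(O)cc2O)C(=O)c2ccc(Br)cc2)cc1`, and varied at the group on the sulfur. In a functional assay on DU-145 cells (Homo sapiens) for inhibition, read by trypan blue exclusion, with a stated time of 96 h (a lower number here means a stronger inhibitor of growth, a higher number a weaker inhibitor of growth), compound 1 reaches only the limit of the assay, > 100000 nM. Compound 2 gives 50000 nM in this assay. Compound 3 also sits at the limit of this assay, > 100000 nM. The measured steps are an at least 2.0-fold lower number from compound 1 to compound 2 (0.30 log units; that floor lies within the scatter), an at least 2.0-fold higher number from compound 2 to compound 3 (0.30 log units; that floor lies within the scatter) and a step that the two limits leave unreadable from compound 1 to compound 3; two of the three values sit at the limit of > 100000 nM in this assay, at which 2 of the 3 values shown sit, so compound 3 stands only as a limit and not as a number.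

Compound 4 `COc1ccc(/C=C(/Sc2ccc(C)cc2)C(=O)c2ccc(Br)cc2)cc1` differs from compound 3 in 4-methoxyphenyl in place of 2,4,6-trihydroxyphenyl on a double-bonded chain carbon bound to a double-bonded chain carbon. Among the compounds with values here, none of the measured steps touches this part of the core; all three concern the group on the sulfur, so no measured step bears directly on the change, and nothing shows what the trihydroxyphenyl contributes. With compound 3 at the limit, the expectation for compound 4 rests on that limit alone: a step of a number no higher from compound 3 to compound 4 (the limit leaves the size open) is expected, that is, nothing readable beyond the scatter. Compound 4 is therefore estimated at 100000 nM, with a range from 30000 nM to 300000 nM, and a further limit rather than a number is the likelier outcome.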

Compound 4, concentration for 50% growth inhibition: 50000 nM
Estimate against measurement, compound 4: 2.0-fold (0.30 log units) above; the measured number falls inside the stated range.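

In this assay, within the data shown here, an at least 2.0-fold lower number from compound 3 to compound 4 (0.30 log units; that floor lies within the scatter) is the first step at this place, on a double-bonded chain carbon bound to a double-bonded chain carbon; all earlier steps concerned the group on the sulfur. The 2,4,6-trihydroxyphenyl is therefore not needed for a readable value with the (4-methylphenyl)sulfanyl group in place: compound 4, whose 4-methoxyphenyl has 0 hydrogen-bond donors, gives 50000 nM. Compound 3 remains a limit and not a number, so this step has only a floor, and its true size stays unread: the limit of > 100000 nM in this assay, at which 2 of the 4 values shown sit.

Open at this place is whether a 4-aminophenyl, a 4-carboxyphenyl or an unsubstituted phenyl would give a number clearly apart from that of the 4-methoxyphenyl. Also open, as far as these compounds go, is whether the (2-bromophenyl)sulfonyl group of compound 2 and the 4-methoxyphenyl of compound 4, taken together in one compound, would move the value beyond the scatter.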